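This account rests on a few compounds, and the source may have more. Where it says the series, first, only, none or still open, it means among the compounds named here.

Compound 1 has the structure `c1ccc2c(-c3cnc4[nH]nc(-c5nc6ccccc6[nH]5)c4c3)cncc2c1` and compound 2 the structure `Cc1cccc2[nH]c(-c3n[nH]c4ncc(-c5cncc6ccccc56)cc34)nc12`. In an assay on isolated protein for inhibition of proto-oncogene tyrosine-protein kinase receptor Ret (Homo sapiens) (on this read-out higher numbers stand for weaker inhibition and lower numbers for stronger inhibition), compound 1 gives "not determined" (no result reported), and in this assay compound 2 gives "not determined" (no result reported). Among the compounds with values here, compound 3, with the structure `COCc1cccc2[nH]c(-c3n[nH]c4ncc(-c5cccnc5)cc34)nc12`, is the only member of this group with a number: in this assay compound 3 gives 1100 nM. Within the data shown here, that single value is therefore the only footing for what follows, and no step between two measured compounds is available to show how large a change such a rearrangement usually brings.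

Compound 4, with the structure `COCc1cccc2[nH]c(-c3n[nH]c4ncc(-c5ccncc5)cc34)nc12`, contains exactly the same atoms as compound 3, joined differently: pyridin-4-yl in place of pyridin-3-yl on an aromatic carbon. The group that leaves and the group that enters each consist of one six-membered aromatic ring with 1 hetero atom, with 0 hydrogen-bond donors and 1 hydrogen-bond acceptor, so nothing is added or lost beyond the position of that ring nitrogen. Among the measured compounds shown here, with no comparable step in hand, the expected change from compound 3 to compound 4 is small, a 1.4-fold higher number from compound 3 to compound 4 (0.13 log units; within the scatter), and not clearly beyond the usual scatter in either direction. For compound 4 in this assay the estimate is 1500 nM, with a likely range from 400 nM to 6000 nM.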

Compound 4, half-maximal inhibitory concentration: > 100000 nM
Compound 4 was reported as a limit; the forecaster's own chance of this, stated with the estimate: 10%; middle value at least 66-fold (1.82 log units) away from the limit.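

Shifting only the ring nitrogen, with pyridin-4-yl in place of pyridin-3-yl on the same aromatic carbon, gives an at least 90-fold higher number from compound 3 to compound 4 (1.95 log units; beyond the scatter), so inhibition is far weaker in compound 4. The value for compound 4 is a limit of the assay and not a number: the limit of > 100000 nM in this assay, at which 1 of the 4 values shown sits. For this pair, then, the place of one ring nitrogen in this group is far from a minor detail, even though the atoms and the counted donors and acceptors stay the same.

The compounds shown leave open whether a plain phenyl ring or pyridin-2-yl at this carbon would behave more like compound 3 or compound 4. They also cannot tell why the ring nitrogen's place matters, or whether the same loss would appear with a different group on the rest of the core.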